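Extending Acetyl to Propanoyl on Compound 3

The compounds below may be only part of what the source reports. "The series", "measured", "known", "first", "only" and "open" are said of these compounds alone.

Measured so far in a functional assay on HeLa cells (Homo sapiens) for antiproliferative activity, read by MTT assay, with a stated time of 72 h (on this read-out lower numbers stand for stronger inhibition and higher numbers for weaker inhibition), are these three compounds
Compound 1 `CCC(=O)NNC(=O)c1csc2ncc(-c3ccc(C)cc3)n12` gives 13000 nM
Compound 2 `CCC(=O)NNC(=O)c1csc2ncc(-c3ccc(OC)cc3)n12` gives 56200 nM
Compound 3 `CC(=O)NNC(=O)c1csc2ncc(-c3ccc(Br)cc3)n12` gives 4780 nM

Compound 3 gives 4780 nM as the lowest of the three numbers and stands apart from compound 1 and compound 2 by more than the scatter. Compound 4 `CCC(=O)NNC(=O)c1csc2ncc(-c3ccc(Br)cc3)n12` has not yet been measured. It departs from compound 3 by methyl in place of hydrogen on a saturated chain carbon bound to a carbonyl carbon in the change of acetyl to propanoyl, with methyl in place of hydrogen on a saturated chain carbon bound to a carbonyl carbon. Going by the values given here, the only measured step of a 4.3-fold higher number from compound 1 to compound 2 (0.64 log units; beyond the scatter) is modest and lies beyond the scatter, yet it is methoxy in place of methyl on an aromatic carbon and says nothing direct about the chain. Among the compounds with values here, compound 1 and compound 2 carry propanoyl but differ from compound 3 on the aromatic group, so no measured pair isolates this change. No step beyond the scatter is therefore expected in this assay for this change. The estimate is a 1.2-fold higher number from compound 3 to compound 4 (0.06 log units; within the scatter) and no more. For compound 4 the estimated value is 5500 nM within a range from 2000 nM to 14000 nM as the expected span.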

Compound 4, half-maximal inhibitory concentration: 23100 nM
Beside the measured number, compound 4's estimate is 4.2-fold (0.62 log units) below it, and the stated range ends below it.
By their numbers in this assay, from the lowest: compound 3; then compounds 1 and 4 (each within the scatter of the next); then compound 2.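

In this assay, going by these compounds alone, the acyl chain proves to matter on the bromo compounds: a 4.8-fold higher number from compound 3 to compound 4 (0.68 log units; beyond the scatter), so methyl in place of hydrogen on a saturated chain carbon bound to a carbonyl carbon gives the only measured step at this position, and it favours acetyl over propanoyl. With propanoyl held constant, the aromatic substituent can also be compared: there is a 2.4-fold lower number from compound 2 to compound 4 (0.39 log units; beyond the scatter) for bromo in place of methoxy, whereas a 1.8-fold higher number from compound 1 to compound 4 (0.25 log units; within the scatter) leaves bromo and methyl unresolved. Nothing available explains the chain step. Only acetyl and propanoyl are shown here, which leaves open how a longer chain such as butanoyl, or a chain ending in an amine, would read. Acetyl appears only with bromo, so whether the chain step also holds with methyl or methoxy on the aromatic carbon remains unknown.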